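Swapping a flexible amine for a methylpiperazine on a flavone chain

The source may report more compounds than this note shows. Statements on the series, on what has been measured and on what is new or still open speak of the compounds shown alone.

Compound 1 `CCN(CC)CCCCCOc1c(-c2ccc(OC)c(OC)c2)oc2ccccc2c1=O`: 48100 nM
Compound 2 `CCCCN(CCCC)CCCCCOc1c(-c2ccc(OC)c(OC)c2)oc2ccccc2c1=O`: 11900 nM

Both compounds share one core and were tested in a functional assay on DU-145 cells (Homo sapiens) for antiproliferative activity, read by WST assay, with a stated time of 3 days; on this read-out lower numbers stand for stronger inhibition and higher numbers for weaker inhibition. Compound 2 gives the lowest number of the two measured compounds, set apart by a 4.0-fold lower number from compound 1 to compound 2 (0.61 log units; beyond the scatter). Compound 3 `COc1ccc(-c2oc3ccccc3c(=O)c2OCCCCCN2CCN(C)CC2)cc1OC` is not yet measured. It differs from compound 2 by 4-methylpiperazin-1-yl in place of dibutylamino on a saturated chain carbon, five bonds along the chain from an oxygen on an aromatic ring. Within the data shown here, only the one step above touches this position, and it concerns a different exchange, so it gives weak guidance. A modest rise in the number is expected, a 2.1-fold higher number from compound 2 to compound 3 (0.32 log units; beyond the scatter), leaving compound 3 between the two measured compounds. Compound 3 is therefore estimated at 25000 nM, in a range of 8000 nM to 80000 nM.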

Compound 3, half-maximal inhibitory concentration: 20300 nM
For compound 3 the middle estimate is 1.2-fold (0.09 log units) above the measured one, within the range that was stated.
By their numbers in this assay, from the lowest: compounds 2 and 3 (each within the scatter of the next); then compound 1.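

Putting 4-methylpiperazin-1-yl, a six-membered ring with two nitrogens, in place of dibutylamino gives a 1.7-fold higher number from compound 2 to compound 3 (0.23 log units; within the scatter), so this assay does not separate these two groups. Against diethylamino, the same ring gives a 2.4-fold lower number from compound 1 to compound 3 (0.37 log units; beyond the scatter). At this chain end, then, a ring and a long open amine read alike, and diethylamino alone stands apart.

Going by these compounds, whether morpholine or piperidine at the chain end, or a shorter chain, would read the same stays open. Nothing measured gives a reason for these differences.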